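The source may report more compounds than this note shows. Statements on the series, on what has been measured and on what is new or still open speak of the compounds shown alone.

Notes on the series. Two compounds have numbers in a functional assay on LS174T cells (Homo sapiens) for inhibition, read by MTT assay, with a stated time of 72 h; a lower number here means a stronger inhibitor, a higher number a weaker inhibitor. Compound 1 `CC(C)c1cc(C(C)C)c(C(=O)/C=C/C(=O)O)c(C(C)C)c1` gives 8280 nM. Compound 2 `O=C(O)/C=C/C(=O)c1ccc(F)cc1` gives 33800 nM, the higher of the two numbers, with compound 1 the nearer one and its lower number lying beyond the scatter. Compound 3 `CC(C)(C)c1ccc(C(=O)/C=C/C(=O)O)cc1` differs from compound 2 by tert-butyl in place of fluoro on an aromatic carbon, on an aromatic carbon of a six-membered aromatic ring of carbon only. Within the data shown here, no step between measured compounds covers this change; the only guide is compound 1, which carries several alkyl groups and gives 8280 nM. For compound 3 the expected step in this assay is a 2.8-fold lower number from compound 2 to compound 3 (0.45 log units; beyond the scatter), downward and beyond the scatter. Compound 3 is estimated at 12000 nM, with a range from 4000 nM to 36000 nM.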

Compound 3, half-maximal inhibitory concentration: 8740 nM
For compound 3 the middle estimate is 1.4-fold (0.14 log units) above the measured one; low and high end bracket the measured number.
By their numbers in this assay, from the lowest: compounds 1 and 3 (each within the scatter of the next); then compound 2.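

Working from a 3.9-fold lower number from compound 2 to compound 3 (0.59 log units; beyond the scatter) in this assay, the aromatic carbon para to a group of 7 heavy atoms proves sensitive to its substituent, with tert-butyl in place of fluoro moving the number beyond the scatter. The earlier pair differed in more than one place and could not show this for a single position. No evidence on hand bears on the reason for this step.

As far as these compounds go, whether a smaller alkyl group such as methyl, or an amine or a methoxy group, would fit the same trend at this position remains open. So does whether tert-butyl acts the same way on another aromatic carbon.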